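This account rests on a few compounds, and the source may have more. Where it says the series, first, only, none or still open, it means among the compounds named here.

Compounds measured in a functional assay for agonist activity at growth hormone secretagogue receptor type 1 (Homo sapiens), read by FLIPR; on this read-out lower numbers stand for smaller maximal responses and higher numbers for larger maximal responses:
compound 1, `COc1ccc(F)c(-c2ccc(S(=O)(=O)Nc3cc(N4C[C@@H](C)N[C@@H](C)C4)ccc3OC)cc2)c1`: 1.2
compound 2, `COc1cccc(-c2ccc(S(=O)(=O)Nc3cc(N4C[C@@H](C)N[C@@H](C)C4)ccc3OC)cc2)c1`: 1
compound 3, `COc1ccc(N2C[C@@H](C)N[C@@H](C)C2)cc1NS(=O)(=O)c1ccc(-c2cnco2)s1`: 0.9

On these numbers compound 2 stands second highest of three: compound 1 sits above it by the step a number 0.20 lower from compound 1 to compound 2 (beyond the scatter), which is beyond the scatter, while compound 3 lies within the scatter of compound 2. Compound 4, `COc1ccc(N2C[C@@H](C)N[C@@H](C)C2)cc1NS(=O)(=O)c1ccc(-c2ccncc2)cc1`, differs from compound 2 in one place: pyridin-4-yl in place of 3-methoxyphenyl on an aromatic carbon. Going by the values given here, the only measured step, from compound 1 to compound 2, concerns a fluoro and was modest; no measured pair isolates the swap of a ring as in compound 4, and compound 3 differs from compound 2 in more than one place. The step a number 0.050 lower from compound 2 to compound 4 (within the scatter) is therefore expected to stay within the scatter. Compound 4 is estimated at 0.95, with a range from 0.75 to 1.15.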

Compound 4, intrinsic activity: the largest response reached, as a fraction of the reference agonist's: 0.7
Estimate against measurement, compound 4: 0.25 above; the measured number lies below the stated range.
By their numbers in this assay, from the lowest: compound 4; then compounds 3 and 2 (each within the scatter of the next); then compound 1.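

Swapping the ring at this position changes the maximal response in this assay: the step a number 0.30 lower from compound 2 to compound 4 (beyond the scatter) is modest, and the step a number 0.50 lower from compound 1 to compound 4 (beyond the scatter) is large. The aryl group on this aromatic carbon therefore matters to the read-out as a whole, not only the fluoro that the earlier step concerned. Nothing available here accounts for the drop.

Pyridin-4-yl brings in a ring nitrogen and removes the methoxy group in the same change, and these two remain unseparated. A plain phenyl or a methoxypyridinyl group at this position would be needed to tell them apart.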